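The source may report more compounds than this note shows. Statements on the series, on what has been measured and on what is new or still open speak of the compounds shown alone.

Compound 1 `CCCCCCCCNC(=O)[C@@H](NC(=O)c1ccco1)[C@@H](C)O` and compound 2 `CCCCCCCCNC(=O)[C@@H](NC(=O)c1cccs1)[C@@H](C)O` share one core and differ only in the ring on the carbonyl carbon. In a functional assay on HepG2 cells (Homo sapiens) for cytotoxicity, read by MTT assay, with a stated time of 48 h (a higher number here means a weaker inhibitor, a lower number a stronger inhibitor), compound 1 gives 192000 nM, the higher of the two numbers, and compound 2 gives 149000 nM; the step of a 1.3-fold lower number from compound 1 to compound 2 (0.11 log units; within the scatter) stays within the scatter. Compound 3 `CCCCCCCCCCCCCCNC(=O)[C@@H](NC(=O)c1ccco1)[C@@H](C)O` differs from compound 1 by hexyl in place of hydrogen on a saturated chain carbon, eight bonds along the chain from an amide-type nitrogen. Among the compounds with values here, no measured step touches this part of the molecule, as the single known step concerns the ring alone. With nothing to guide it, the step of a 1.3-fold lower number from compound 1 to compound 3 (0.11 log units; within the scatter) is expected to stay within the scatter. Compound 3 is therefore estimated at 150000 nM, between 50000 nM and 350000 nM.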

Compound 3, half-maximal inhibitory concentration: > 400000 nM
Compound 3: no number, only a limit (the forecaster's own chance of this, stated with the estimate: 20%); middle value at least 2.6-fold (0.42 log units) from the limit.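

In this assay, hexyl in place of hydrogen on a saturated chain carbon, eight bonds along the chain from an amide-type nitrogen, gives an at least 2.0-fold higher number from compound 1 to compound 3 (0.31 log units; beyond the scatter). Within the data shown here, this chain position therefore moves the result beyond the scatter towards a weaker inhibitor, which the ring change between the earlier compounds did not do. The value for compound 3 is a limit, not a number, so the full size of this step stays unknown: the limit of > 400000 nM in this assay, at which 1 of the 3 values shown sits.

The compounds shown leave open how a shorter chain, a longer chain or an amine at the chain end would read. They also leave open whether thiophen-2-yl would give the same result on the chain of compound 3.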